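This account rests on a few compounds, and the source may have more. Where it says the series, first, only, none or still open, it means among the compounds named here.

Working notes on the series, read in a functional assay on HCT-116 cells (Homo sapiens) for antiproliferative activity, read by MTT assay, with a stated time of 72 h; on this read-out higher numbers stand for weaker inhibition and lower numbers for stronger inhibition. Compound 1 `CCNC(=O)CCc1cccc2c1B(O)OC2` gives > 100000 nM, which is a limit of the assay and not a number. Compound 2 `O=C(CCc1cccc2c1B(O)OC2)Nc1ccccc1` gives 350 nM and compound 3 `COc1ccccc1NC(=O)CCc1cccc2c1B(O)OC2` gives 430 nM, two values within the scatter of each other. Compound 3 therefore stands level with compound 2, and both lie far from the limit reached by compound 1.

Compound 4 `C#Cc1ccccc1NC(=O)CCc1cccc2c1B(O)OC2` has ethynyl in place of methoxy on an aromatic carbon, ortho to a large group: ethynyl in place of methoxy on an aromatic carbon.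

Within the data shown here, two measured steps bear on this change. The large one, an at least 280-fold lower number from compound 1 to compound 2 (2.45 log units; beyond the scatter), concerns the amide-type nitrogen, and the phenyl placed there is kept in compound 3 and compound 4, so it sets the level of the series rather than the size of the next step. The closer guide is a 1.2-fold higher number from compound 2 to compound 3 (0.09 log units; within the scatter), a change on the same ring that stays within the scatter. This is a single example, so the range is kept wide. No step beyond the scatter is expected in this assay, and no direction is favoured with any confidence.

The estimated step is a 1.1-fold lower number from compound 3 to compound 4 (0.05 log units; within the scatter). For compound 4 the expected value is 380 nM, with an estimated range from 130 nM to 1100 nM.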

Compound 4, half-maximal inhibitory concentration: 1400 nM
The estimate for compound 4 lay 3.7-fold (0.57 log units) below the measured number; measured number above the stated range.
By their numbers in this assay, from the lowest: compounds 2 and 3 (each within the scatter of the next); then compound 4. At a limit, above all of these: compound 1.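

In this assay the aromatic carbon ortho to a large group proves sensitive to the group it carries: ethynyl in place of methoxy gives a 3.3-fold higher number from compound 3 to compound 4 (0.51 log units; beyond the scatter) and lies beyond the scatter, while methoxy in place of hydrogen gave a 1.2-fold higher number from compound 2 to compound 3 (0.09 log units; within the scatter) and stayed within it. The change is also seen against the unsubstituted phenyl amide, since ethynyl in place of hydrogen gives a 4.0-fold higher number from compound 2 to compound 4 (0.60 log units; beyond the scatter) and again lies beyond the scatter, so this carbon does not accept every small group equally, even though methoxy and ethynyl each count the same number of heavy atoms under the comparison of the two structures. No measurement among those shown speaks to why ethynyl and methoxy part here.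

The compounds shown leave open how far this reading extends to other groups on the same carbon, such as an amine, a nitrile or a carboxylic acid, and whether any of them would stay level with compound 2 and compound 3. Among these compounds, also open is whether ethynyl or methoxy would read the same way on the other carbons of this ring, where the series offers no example so far.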